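The compounds below may be only part of what the source reports. "The series", "measured", "known", "first", "only" and "open" are said of these compounds alone.

Measured in a physicochemical assay for lipophilicity, read by HPLC; a higher number here means a more lipophilic compound, a lower number a more polar compound:

compound 1 `O=C(Nc1ccccc1Br)c1ccc2cccc(O)c2n1`: 2.5
compound 2 `O=C(Nc1cccc(Br)c1)c1ccc2cccc(O)c2n1`: 2.5
compound 3 `O=C(Nc1ccccc1C(F)(F)F)c1ccc2cccc(O)c2n1`: 2.5

Compound 1 and compound 2 share all atoms and differ only in 3-bromophenyl in place of 2-bromophenyl on an amide-type nitrogen; in this assay the step is no change at the digits printed from compound 1 to compound 2 (within the scatter). Compound 1 and compound 3 differ in trifluoromethyl in place of bromo on an aromatic carbon, and the step is no change at the digits printed from compound 1 to compound 3 (within the scatter). Compound 2 thus stands level with compound 1 and compound 3 at the digits read.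

Compound 4 `O=C(Nc1cccc(C(F)(F)F)c1)c1ccc2cccc(O)c2n1` is not yet measured. It differs from compound 2 in trifluoromethyl in place of bromo on an aromatic carbon. This is the same kind of change as that from compound 1 to compound 3, though the place differs: ortho to a large group there, meta to a large group here.

In this assay the step is expected to be no change at the digits printed from compound 2 to compound 4 (within the scatter) because no change at the digits printed from compound 1 to compound 3 (within the scatter) under the same kind of change. Compound 4 is estimated at 2.5, between 2.2 and 2.8.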

Compound 4, partition coefficient: 2.5
The estimate for compound 4 equals the measured number at the digits printed, and the stated range covers the measured number.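

Working notes on the series: in this assay, trifluoromethyl in place of bromo gives no change at the digits printed from compound 2 to compound 4 (within the scatter), matching no change at the digits printed from compound 1 to compound 3 (within the scatter), so the change reads the same in the 2-substituted and 3-substituted phenyl amides. This supports carrying the change between these two closely related compounds on the shared core, but it rests on two pairs in one assay and does not show that the result transfers to a different core. Nothing available bears on the cause of this result.

The compounds shown leave open how an amine, a carboxylic acid or a longer chain in place of bromo or trifluoromethyl would read. Going by these compounds, whether the same change holds on any other core also remains open.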